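Three Limits and an Expected Fourth

The source may report more compounds than this note shows. Statements on the series, on what has been measured and on what is new or still open speak of the compounds shown alone.

Compound 1 `CS(=O)(=O)c1ccc(C(=O)N2CCC(C(=O)N(Cc3ccccc3)c3ccccc3)CC2)cc1[N+](=O)[O-]` gives > 27000 nM in an ADME assay on HepG2 cells (Homo sapiens) for cytotoxicity, read by CellTiter-Glo and ATP content, with a stated time of 72 h (on this read-out lower numbers stand for an effect already at smaller amounts and higher numbers for an effect only at larger amounts of compound), which is a limit of the assay.
Compound 2 `CS(=O)(=O)c1ccc(C(=O)N2CCC(C(=O)N3CCN(c4ccc(F)cc4)CC3)CC2)cc1[N+](=O)[O-]` gives > 27000 nM in this assay, again a limit.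
Compound 3 `CCCN(C(=O)CN(C)C(=O)c1ccc(S(C)(=O)=O)c([N+](=O)[O-])c1)c1ccccc1` gives > 27000 nM in this assay, also a limit.

None of the three compounds yields a number: every value sits at the same limit (the limit of > 27000 nM in this assay, at which 3 of the 3 values shown sit). Compound 3 therefore stands where the other two stand, at the edge of what this assay reports, and nothing separates it from compound 1 or compound 2 on the figures shown.

Compound 4 `CN(CC(=O)N1CCc2ccccc2C1)C(=O)c1ccc(S(C)(=O)=O)c([N+](=O)[O-])c1` has not yet been measured in this assay. It differs from compound 3 by 1,2,3,4-tetrahydroisoquinolin-2-yl in place of phenyl(propyl)amino on a carbonyl carbon. Going by the values given here, no step between measured compounds is available to set the size of such a change, so the expectation rests on the shared limit alone. The step from compound 3 to compound 4 is expected to be a number no higher from compound 3 to compound 4 (the limit leaves the size open), nothing beyond the scatter. Compound 4 is accordingly estimated at 27000 nM, within a range from 15000 nM to 60000 nM, and most probably reported once more only as a limit.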

Compound 4, half-maximal effective concentration: > 27000 nM
Compound 4 was reported as a limit; the forecaster's own chance of this, stated with the estimate: 85%; the middle value sits exactly at the limit.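

Compound 3 and compound 4 both stand only as limits, and no step can be read between them: the limit of > 27000 nM in this assay, at which 4 of the 4 values shown sit. The compounds shown leave open whether 1,2,3,4-tetrahydroisoquinolin-2-yl in place of phenyl(propyl)amino changes anything in this assay, and how the four compounds would rank there.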